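This account rests on a few compounds, and the source may have more. Where it says the series, first, only, none or still open, it means among the compounds named here.

Measured in a functional assay on cells (Homo sapiens) for inhibition; a lower number here means a stronger inhibitor, a higher number a weaker inhibitor:
compound 1 `CN(O)/C=C\C(=O)c1ccc([N+](=O)[O-])cc1`: > 10000 nM, a limit
compound 2 `O=C(/C=C\N(O)Cc1ccccc1)c1ccc([N+](=O)[O-])cc1`: 1700 nM
compound 3 `O=C(/C=C\N(O)Cc1ccccc1)c1ccc(Cl)c(Cl)c1`: 3600 nM

Compound 1 has no number, only a limit. It stands at the limit of > 10000 nM in this assay, at which 1 of the 3 values shown sits.

Compound 4 `CN(O)/C=C\C(=O)c1ccc(F)cc1` keeps the core of compound 1 and changes one group, with fluoro in place of nitro on an aromatic carbon.

Going by the values given here, no measured step makes this exchange. Among the compounds with values here, the only measured step, an at least 5.8-fold lower number from compound 1 to compound 2 (0.76 log units; beyond the scatter), lies at another place, phenyl in place of hydrogen on a saturated chain carbon bound to an amine nitrogen, and compound 4 does not carry that phenyl. The nearest guide on the aromatic substituents is a pair that shares the phenyl: compound 2 gives 1700 nM and compound 3 gives 3600 nM. Both of these are measurable numbers despite different aromatic substituents, so a large gain from the aromatic exchange alone is not expected. Without the phenyl, compound 4 is expected to stay close to the limit of compound 1, with no step beyond the scatter and no direction that can be set.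

The expected change is a step that the limit leaves unreadable from compound 1 to compound 4, which is an estimate made against a limit and not against a number.

The estimate for compound 4 is 12000 nM, with an expected range of 4000 nM to 40000 nM.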

Compound 4, half-maximal inhibitory concentration: 5500 nM
The estimate for compound 4 lay 2.2-fold (0.34 log units) above the measured number; measured number inside the range.
By their numbers in this assay, from the lowest: compound 2; then compounds 3 and 4 (each within the scatter of the next). At a limit, above all of these: compound 1.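

In this assay compound 4 gives 5500 nM, which shows that a readable number in this short series does not depend on the phenyl on the chain carbon: fluoro on the aromatic carbon, para to a group of 7 heavy atoms, is enough to yield one on the core of compound 1. Compound 1 stands at a limit, > 10000 nM, and not at a number. Read against that limit, the exchange of nitro for fluoro gives an at least 1.8-fold lower number from compound 1 to compound 4 (0.25 log units; that floor lies within the scatter), so a real gain at this position is not established, and the true size of the step cannot be fixed from these values: the limit of > 10000 nM in this assay, at which 1 of the 4 values shown sits.

Open, going by these compounds, is how fluoro at this position behaves together with the phenyl, and whether the change seen with the phenyl, an at least 5.8-fold lower number from compound 1 to compound 2 (0.76 log units; beyond the scatter), would keep its size on that background. Also open, on these data alone, is what an amine or a carboxylic acid on the same aromatic carbon would give, and how a longer chain in place of the phenyl would compare on the nitrogen of the shared core.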